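Growth inhibition after one group swap on compound 3

The source may hold more compounds than are shown below. What is called first, only, known or untested is meant among the compounds shown, and "the series" means these compounds.

Values in a functional assay on DU-145 cells (Homo sapiens) for inhibition, read by trypan blue exclusion, with a stated time of 96 h (a higher number here means a weaker inhibitor of growth, a lower number a stronger inhibitor of growth), for the measured compounds:
Compound 1 `Cc1ccc(CS/C(=C/c2c(O)cc(O)cc2O)C(=O)c2ccc(Cl)cc2)cc1` gives 50000 nM (a number)
Compound 2 `Cc1ccc(S(=O)(=O)/C(=C/c2c(O)cc(O)cc2O)C(=O)c2ccc(Br)cc2)cc1` gives > 100000 nM (a limit)
Compound 3 `COc1ccc(/C=C(\C(=O)c2ccc(Cl)cc2)S(=O)(=O)c2ccc(C)cc2)cc1O` gives 1000 nM (a number)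

Of the two actual numbers, compound 3 holds the lower one, and the gap up to compound 1 lies beyond the scatter. For compound 2 the reading of > 100000 nM is a limit of the assay and not a number.

The step to compound 4 `Cc1ccc(S(=O)(=O)/C(=C/c2c(O)cc(O)cc2O)C(=O)c2ccc(Cl)cc2)cc1` puts 2,4,6-trihydroxyphenyl in place of 3-hydroxy-4-methoxyphenyl on a double-bonded chain carbon bound to a double-bonded chain carbon, counted as 2,4,6-trihydroxyphenyl in place of 3-hydroxy-4-methoxyphenyl on a double-bonded chain carbon bound to a double-bonded chain carbon in full.

Going by the values given here, no measured pair differs in one place only, so the guide is indirect. Compound 1 also carries 2,4,6-trihydroxyphenyl and gives 50000 nM in this assay despite other differences. Compound 2 carries it as well, and its > 100000 nM is again only a limit. A large step towards a higher number, beyond the scatter, is therefore expected. The estimated change is a 50-fold higher number from compound 3 to compound 4 (1.70 log units; beyond the scatter) and it would mean weaker growth inhibition. For compound 4 the expected value is 50000 nM (estimated range 12000 nM to 100000 nM).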

Compound 4, concentration for 50% growth inhibition: > 100000 nM
Compound 4: a limit, no number; the forecaster's own chance of this, stated with the estimate: 40%; middle value at least 2.0-fold (0.30 log units) away from the limit.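

In this assay, the swap of 2,4,6-trihydroxyphenyl in place of 3-hydroxy-4-methoxyphenyl on a double-bonded chain carbon bound to a double-bonded chain carbon now gives a direct reading, an at least 100-fold higher number from compound 3 to compound 4 (2.00 log units; beyond the scatter), so the aryl group at this place has a large bearing on growth inhibition while the rest of the molecule stays the same. The change to (4-methylphenyl)sulfonyl in place of (4-methylbenzyl)sulfanyl gives an at least 2.0-fold higher number from compound 1 to compound 4 (0.30 log units; that floor lies within the scatter), so no clear effect can be claimed for it, and the step for chloro in place of bromo cannot be read. Both readable sizes are only floors, because compound 4 gives a limit and not a number: the limit of > 100000 nM in this assay, at which 2 of the 4 values shown sit.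

The compounds shown leave open whether the loss follows the departure of the methoxy group or the arrival of the additional hydroxy groups. As far as these compounds go, whether an aryl group carrying an amine or a carboxylic acid at this place would match compound 3 also remains open.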